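Chloro on the naphthyl ring of a thiophene ketone

The source may report more compounds than this note shows. Statements on the series, on what has been measured and on what is new or still open speak of the compounds shown alone.

Compound 1 `Nc1sc2c(c1C(=O)c1ccc(Br)c3ccccc13)CCC2`: 0%
Compound 2 `Nc1sc2c(c1C(=O)c1cccc3ccccc13)CCCC2`: 2%

In an assay on isolated protein with adenosine receptor A1 (Homo sapiens) as the target, tested at 10 uM (on this read-out lower numbers stand for less inhibition and higher numbers for more inhibition at the one concentration tested (going by the name of the read-out)), compound 2 gives 2%, and compound 1 gives 0%, so the two values lie within the usual scatter of each other and neither stands apart. Compound 3 `Nc1sc2c(c1C(=O)c1ccc(Cl)c3ccccc13)CCCC2` is not yet measured in this assay. It differs from compound 2 by chloro in place of hydrogen on an aromatic carbon. Among the measured compounds shown here, no step between measured compounds shows the effect of such a change, so no step beyond the scatter is expected here. The step of a number 1 percentage points higher from compound 2 to compound 3 (within the scatter) is the estimate. Compound 3 is expected to give 3%, within -8% to 15%.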

Compound 3, a percentage reported as inhibition, at one concentration (the size of the read-out at that concentration, not a potency): 4.8%
Beside the measured number, compound 3's estimate is 1.8 percentage points below it; measured number inside the range.
By their numbers in this assay, from the lowest: compounds 1, 2 and 3 (each within the scatter of the next).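

In this assay, among the compounds shown here, chloro in place of hydrogen on an aromatic carbon, para to a large group, gives a number 2.8 percentage points higher from compound 2 to compound 3 (within the scatter), the only step that can be read at this position. On this core, the change therefore leaves the read-out within the scatter. Nothing available explains this result. Going by these compounds, whether an amine or a carboxylic acid at this same position would give a step beyond the scatter remains open, and so does whether a change elsewhere on the core would.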